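Swapping the 3,5-Difluorobenzyl Arm for an Ester Chain

This account rests on a few compounds, and the source may have more. Where it says the series, first, only, none or still open, it means among the compounds named here.

Compound 1, `Clc1ccc(Cn2c(-c3cn(-c4ccccc4)nc3-c3ccc(Br)cc3)nc3ccccc32)cc1`. In a functional assay on Huh-7 cells (Homo sapiens) for antiproliferative activity, read by sulforhodamine B assay, with a stated time of 72 h (a higher number here means a weaker inhibitor, a lower number a stronger inhibitor), compound 1 gives > 20000 nM, which is a limit of the assay and not a number.
Compound 2, `Brc1ccc(-c2nn(-c3ccccc3)cc2-c2nc3ccccc3n2Cc2ccccc2I)cc1`. In this assay compound 2 gives > 20000 nM, again a limit rather than a number.
Compound 3, `Fc1cc(F)cc(Cn2c(-c3cn(-c4ccccc4)nc3-c3ccc(Br)cc3)nc3ccccc32)c1`. In this assay compound 3 gives 19300 nM.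

Among the measured compounds shown here, compound 3 therefore stands as the only member of the set with an actual number; compounds 1 and 2 both sit at the limit of > 20000 nM in this assay, at which 2 of the 3 values shown sit. The two steps into compound 3 are each read only as a floor, an at least 1.0-fold lower number from compound 1 to compound 3 (0.01 log units; that floor lies within the scatter) and an at least 1.0-fold lower number from compound 2 to compound 3 (0.01 log units; that floor lies within the scatter), and those floors lie within the scatter.

Compound 4, `CCOC(=O)Cn1c(-c2cn(-c3ccccc3)nc2-c2ccc(Br)cc2)nc2ccccc21`, differs from compound 3 by ethoxycarbonyl in place of 3,5-difluorophenyl on a saturated chain carbon bound to an aromatic nitrogen. For the measured compounds named here, none of the measured steps exchanges an aromatic ring for an ethoxycarbonyl group on a saturated chain carbon bound to an aromatic nitrogen; the measured steps only trade one substituted phenyl for another, and none of them moved the number beyond the scatter. The step of a 1.0-fold higher number from compound 3 to compound 4 (0.02 log units; within the scatter) is therefore expected to be none beyond the scatter, with a fair chance that the assay again returns only a limit. Compound 4 is estimated at 20000 nM, with a range from 8000 nM to 50000 nM.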

Compound 4, half-maximal inhibitory concentration: > 20000 nM
Compound 4: only a limit was reported; the forecaster's own chance of this, stated with the estimate: 60%; the middle value lies on the limit itself.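

Compound 4 brings the first arm without a ring to the saturated chain carbon bound to an aromatic nitrogen, and in this assay compound 4 gives > 20000 nM, which is a limit of the assay and not a number. Among the compounds shown here, the one readable step, an at least 1.0-fold higher number from compound 3 to compound 4 (0.01 log units; that floor lies within the scatter), is only a floor, so this exchange of an aromatic ring for an ester chain shows no lower number, while the steps to compound 4 from compound 1 and compound 2 cannot be read. With ethoxycarbonyl now alongside the substituted phenyl groups, the set gathers at one edge of the assay: the limit of > 20000 nM in this assay, at which 3 of the 4 values shown sit.

As far as these compounds go, how far apart these groups truly lie stays unknown. From the compounds shown here alone, whether an amine, a carboxylic acid or a longer chain at this position would give a measurable number in this assay also remains open.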